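A few compounds are considered here, and "the series" means these few. Any claim that something is new, unique, unknown or untested is made for them only; others in the source may bear on it.

Measured compounds in the series:
- compound 1, `COc1cc(Br)cc2c1OC(N)=C(C#N)C2CC(=O)c1ccccc1`, in a functional assay on MCF7 cells (Homo sapiens) for antiproliferative activity, read by sulforhodamine B assay, with a stated time of 72 h, tested at 30 uM (on this read-out higher numbers stand for a weaker effect at the one concentration tested and lower numbers for a stronger effect), compound 1 gives 36.7%
- compound 2, `COc1cccc(C(=O)CC2C(C#N)=C(N)Oc3c(OC)cc(Br)cc32)c1`, in this assay compound 2 gives 33.9%

For the measured compounds named here, compound 2 and compound 1 lie within the scatter of each other; the one measured step, a number 2.8 percentage points lower from compound 1 to compound 2 (within the scatter), is within the scatter, so the two numbers show no separation on the shared core at this concentration.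

Compound 3, `COc1cc(Br)cc2c1OC(N)=C(C#N)C2CC(=O)c1ccc(Br)cc1`, is not yet measured. The change from compound 2 is 4-bromophenyl in place of 3-methoxyphenyl on a carbonyl carbon. Going by the values given here, no measured step touches this part of the molecule: the only step known, a number 2.8 percentage points lower from compound 1 to compound 2 (within the scatter), concerns a methoxy on the other aromatic ring and stays within the scatter. There is thus no measured basis for a move beyond the scatter in either direction in this assay, and the expectation is that compound 3 stays near compound 2.

Compound 3 is therefore expected to give 35%, with a range from 20% to 55%. The estimated step from compound 2 to compound 3, a number 1.1 percentage points higher from compound 2 to compound 3 (within the scatter), is expected to fall within the scatter.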

Compound 3, a percentage reported as activity, at one concentration (the size of the read-out at that concentration, not a potency): 33.1%
Beside the measured number, compound 3's estimate is 1.9 percentage points above it, within the range that was stated.
By their numbers in this assay, from the lowest: compounds 3, 2 and 1 (each within the scatter of the next).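

In this assay the group on a carbonyl carbon whose other neighbours are a saturated chain carbon has now been varied directly. 4-bromophenyl in place of 3-methoxyphenyl gives a number 0.8 percentage points lower from compound 2 to compound 3 (within the scatter) and bromo in place of hydrogen on an aromatic carbon gives a number 3.6 percentage points lower from compound 1 to compound 3 (within the scatter) so neither exchange separates from the other compounds at this place. The earlier step covered only a methoxy, whereas these two steps show that a bromo on this aromatic ring, and the swap of one substituted ring for another, also leave the three compounds without separation on the shared core at this concentration. No evidence is available that bears on why these numbers stay together.

As far as these compounds go, whether any group at this place can move the read-out beyond the scatter stays open, for instance an amine or a carboxylic acid on the aromatic ring, or a longer chain in place of the saturated chain carbon. From the compounds shown here alone, the read-out gives only the size of the effect at one concentration, so whether the three compounds would show a stronger or weaker effect than one another at any other concentration remains open as well.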